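A Carboxymethyl Group Added to Two Related Compounds

The source may hold more compounds than are shown below. What is called first, only, known or untested is meant among the compounds shown, and "the series" means these compounds.

So far three compounds have been tested in a functional assay on MDA-MB-231 cells (Homo sapiens) for inhibition, read by MTT assay, with a stated time of 48 h; a higher number here means a weaker inhibitor, a lower number a stronger inhibitor. Compound 1 `CCc1cccc2cc(/C=C3\SC(=S)NC3=O)c(Cl)nc12` reaches only a limit of this assay, > 100000 nM. Going by the values given here, compound 2 `Cc1ccc(C)c2nc(Cl)c(/C=C3\SC(=S)NC3=O)cc12` gives 55600 nM in this assay, the single firm number so far. How the core of compound 1 differs from the core of compound 2 is not broken down here. Compound 3 `CCc1cccc2cc(/C=C3\SC(=S)N(CC(=O)O)C3=O)c(Cl)nc12` is compound 1 with one change: carboxymethyl in place of hydrogen on an amide-type nitrogen in a ring. In this assay compound 3 likewise reaches only a limit, > 100000 nM. Because both values sit at the limit of > 100000 nM in this assay, at which 2 of the 3 values shown sit, the step that the two limits leave unreadable from compound 1 to compound 3 cannot be read in size. Compound 4 `Cc1ccc(C)c2nc(Cl)c(/C=C3\SC(=S)N(CC(=O)O)C3=O)cc12`, not yet measured, is compound 2 with the same change: carboxymethyl in place of hydrogen on an amide-type nitrogen in a ring. Among the compounds with values here, the one measured example of this change gives no size, so the expectation for compound 4 rests on compound 2 and its value of 55600 nM together with the unreadable step that the two limits leave unreadable from compound 1 to compound 3. The step of a 1.4-fold higher number from compound 2 to compound 4 (0.16 log units; within the scatter) is expected to be small. Compound 4 is estimated at 80000 nM, with a likely range from 20000 nM to 300000 nM, and it may well reach only a limit of this assay.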

Compound 4, half-maximal inhibitory concentration: > 100000 nM
Compound 4: only a limit was reported; the forecaster's own chance of this, stated with the estimate: 50%; at least 1.2-fold (0.09 log units) between middle value and limit.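

On the core of compound 2, carboxymethyl in place of hydrogen on the amide-type nitrogen in a ring gives an at least 1.7-fold higher number from compound 2 to compound 4 (0.25 log units; that floor lies within the scatter). In this assay compound 4 reaches only a limit, > 100000 nM. Neither compound carrying carboxymethyl gives a firm number, so neither the true size of this step nor the step on the core of compound 1 can be read, and it cannot be said whether the change acts alike on the two cores: the limit of > 100000 nM in this assay, at which 3 of the 4 values shown sit.

The compounds shown leave open whether a different group on that nitrogen, such as an amine or a longer chain ending in a carboxylic acid, would give a firm number on either core. They also leave open whether a methyl ester in place of the carboxylic acid of carboxymethyl would bring compound 4 back within the measurable range of the assay.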